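Chloro for Fluoro: Estimating Compound 3 in Glucagon Binding

The compounds below may be only part of what the source reports. "The series", "measured", "known", "first", "only" and "open" are said of these compounds alone.

Measured so far:
Compound 1 `CCCC(Oc1ccc(-n2cc(OC)cn2)cc1)c1ccc(C(=O)NCCC(=O)O)cc1` gives 4400 nM in an assay on cells for displacement of a labelled ligand from Glucagon receptor (Homo sapiens), in the presence of a further agent that is not named here; on this read-out higher numbers stand for weaker inhibition and lower numbers for stronger inhibition.
Compound 2 `CCCC(Oc1ccc(-n2cc(F)cn2)cc1)c1ccc(C(=O)NCCC(=O)O)cc1` gives 1700 nM in this assay.

Compound 2 stands lowest of the two numbers; the gap to the other is the step of a 2.6-fold lower number from compound 1 to compound 2 (0.41 log units; beyond the scatter), which lies beyond the scatter. Compound 3 `CCCC(Oc1ccc(-n2cc(Cl)cn2)cc1)c1ccc(C(=O)NCCC(=O)O)cc1` has not yet been measured. It differs from compound 2 in one place: chloro in place of fluoro on an aromatic carbon. Within the data shown here, no measured step exchanges fluoro for chloro, so none bears directly on this change. The only step shown, a 2.6-fold lower number from compound 1 to compound 2 (0.41 log units; beyond the scatter), exchanged methoxy for fluoro, a different change, and it was modest. On that basis compound 3 is expected to stay close to compound 2 in this assay, with a step of about a 1.3-fold lower number from compound 2 to compound 3 (0.12 log units; within the scatter) whose direction is uncertain and which may well lie within the scatter. Compound 3 is therefore estimated at 1300 nM, within a range from 450 nM to 3800 nM.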

Compound 3, inhibition constant: 1100 nM
Compound 3: middle estimate off by 1.2-fold (0.07 log units), on the high side; the range from low to high includes it.
By their numbers in this assay, from the lowest: compounds 3 and 2 (each within the scatter of the next); then compound 1.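

In this assay, replacing fluoro with chloro on this carbon of the pyrazole gives a 1.5-fold lower number from compound 2 to compound 3 (0.19 log units; within the scatter) and so does not separate the two halogens at this position. Chloro, like fluoro, also stands apart from methoxy at the same place, with a 4.0-fold lower number from compound 1 to compound 3 (0.60 log units; beyond the scatter) alongside a 2.6-fold lower number from compound 1 to compound 2 (0.41 log units; beyond the scatter) for fluoro, and no listed compound goes against this. No measurement available here accounts for either the closeness of the two halogens or their gap from methoxy.

The compounds shown leave open whether a bromo, nitrile or trifluoromethyl group on this carbon would move the number beyond the scatter from chloro, and where a plain hydrogen there would stand. They also leave open whether the closeness of fluoro and chloro would persist with another group in place of the carboxylic acid.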